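Swapping the ring on the shared core: compound 2 to compound 4

The compounds below may be only part of what the source reports. "The series", "measured", "known", "first", "only" and "open" are said of these compounds alone.

Of the compounds shown here, three sharing one core have been tested in a functional assay on A549 cells (Homo sapiens) for inhibition, read by MTT assay, with a stated time of 72 h, tested at 20 uM; on this read-out lower numbers stand for less inhibition and higher numbers for more inhibition at the one concentration tested (going by the name of the read-out). Compound 1 `CN(c1ccc(Oc2ncnc3sccc23)cc1)c1nccc(N2CCCCC2)n1` gives 51.9%. Compound 2 `c1cc(N2CCCCC2)nc(Nc2ccc(Oc3ncnc4sccc34)cc2)n1` gives 64.8%, the highest of the three numbers, though compound 3 `c1cc(N2CCCCC2)nc(Nc2ccc(Oc3ncnc4ccsc34)cc2)n1` with 59.9% sits within the scatter of it. The step of a number 12.9 percentage points higher from compound 1 to compound 2 (beyond the scatter) is the only one beyond the scatter, while the step of a number 4.9 percentage points lower from compound 2 to compound 3 (within the scatter) is not.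

Compound 4 `c1ccc2c(c1)CCN(c1ccnc(Nc3ccc(Oc4ncnc5sccc45)cc3)n1)C2` has not yet been measured. It differs from compound 2 in one place: 1,2,3,4-tetrahydroisoquinolin-2-yl in place of piperidin-1-yl on an aromatic carbon. Among the measured compounds shown here, neither measured step touches the piperidin-1-yl group, so no step bears directly on this change; the one step beyond the scatter concerned a methyl on a nitrogen, and the other the exchange of one bicyclic group for another on an oxygen. Without a comparable step, the expectation is a number close to that of compound 2, with a wide range on either side. The estimated step is a number 2.8 percentage points lower from compound 2 to compound 4 (within the scatter). Compound 4 is therefore expected to give 62%, most likely between 40% and 80%.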

Compound 4, a percentage reported as inhibition, at one concentration (the size of the read-out at that concentration, not a potency): 34%
Estimate against measurement, compound 4: 28 percentage points above; measured number outside the range, below it.
By their numbers in this assay, from the lowest: compound 4; then compounds 1, 3 and 2 (each within the scatter of the next, the first and the last beyond it).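

In this assay, among the compounds shown here, the change at this aromatic carbon produces a number 30.8 percentage points lower from compound 2 to compound 4 (beyond the scatter), the only step marked as large. For the compounds shown here, this position is therefore not indifferent to the group it carries, a point the earlier steps could not show because neither touched it. The two groups match in hydrogen-bond donors, hydrogen-bond acceptors and net charge, while 1,2,3,4-tetrahydroisoquinolin-2-yl also carries a six-membered aromatic ring of carbon only, but no measurement here explains the lower number.

Going by these compounds, it remains open whether a morpholin-4-yl or a dimethylamino group in place of piperidin-1-yl would keep the number close to that of compound 2. On these data alone, it is also open whether 1,2,3,4-tetrahydroisoquinolin-2-yl would lower the number to a similar extent on the core of compound 3.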